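The compounds below may be only part of what the source reports. "The series", "measured", "known", "first", "only" and "open" are said of these compounds alone.

Compound 1 `COc1ccc(CN2C(=O)/C(=C/c3cc(C)n(-c4ccc(O)c(C(=O)O)c4)c3C)SC2=S)cc1` gives 75300 nM in an ADME assay on MT2 cells (Homo sapiens) for cytotoxicity, read by XTT assay, with a stated time of 4 days; on this read-out higher numbers stand for lower toxicity in this test and lower numbers for higher toxicity in this test. For the measured compounds named here, compound 2 `Cc1cc(/C=C2\SC(=S)N(Cc3cccc(Br)c3)C2=O)c(C)n1-c1ccc(O)c(C(=O)O)c1` gives 48200 nM in this assay; the only measured step is a 1.6-fold lower number from compound 1 to compound 2 (0.19 log units; within the scatter), a gap within the scatter, where 3-bromophenyl replaced 4-methoxyphenyl on a saturated chain carbon bound to an amide-type nitrogen in a ring. Compound 3 `Cc1cc(/C=C2\SC(=S)N(Cc3ccccc3Br)C2=O)c(C)n1-c1ccc(O)c(C(=O)O)c1` differs from compound 2 by 2-bromophenyl in place of 3-bromophenyl on a saturated chain carbon bound to an amide-type nitrogen in a ring. Going by the values given here, the only measured step bears on it directly, since it also changed the group at that place, and it stayed within the scatter; no step beyond the scatter is therefore expected, a 1.0-fold higher number from compound 2 to compound 3 (0.02 log units; within the scatter). Compound 3 is estimated at 50000 nM, with a range from 25000 nM to 100000 nM.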

Compound 3, half-maximal cytotoxic concentration: 25700 nM
Beside the measured number, compound 3's estimate is 1.9-fold (0.29 log units) above it; low and high end bracket the measured number.
By their numbers in this assay, from the lowest: compounds 3, 2 and 1 (each within the scatter of the next, the first and the last beyond it).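

In this assay, the change from 3-bromobenzyl to 2-bromobenzyl gives a 1.9-fold lower number from compound 2 to compound 3 (0.27 log units; within the scatter), so these two bromophenyl groups are not separated at this place. Set against 4-methoxyphenyl, 2-bromophenyl gives a 2.9-fold lower number from compound 1 to compound 3 (0.47 log units; beyond the scatter), the first step at this place to clear the scatter, though only modestly, and its direction is towards higher toxicity in this test. No evidence bearing on the origin of this step is available. Open, going by these compounds, is how 4-bromophenyl or plain phenyl would read at this place. Also open, on these data alone, is whether an amine or a longer chain there would hold the numbers in this range.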